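A Prenyl Chain in Place of a Hydroxylated Chain

The source may report more compounds than this note shows. Statements on the series, on what has been measured and on what is new or still open speak of the compounds shown alone.

Compound 1 `CC(C)=CCc1cc(C2=C(O)/C(=C/c3ccc(O)c(CCC(C)(C)O)c3)OC2=O)c(O)cc1O` gives 3100 nM in a functional assay on J774.1 cells (Mus musculus), read by LDH release, with a stated time of 1 h, in the presence of a further agent that is not named here (on this read-out higher numbers stand for weaker inhibition and lower numbers for stronger inhibition), the lowest of the two numbers recorded so far; compound 2 `CC(C)=CCc1cc(C2=C(O)/C(=C/c3ccc4c(c3)C[C@H](C(C)(C)O)O4)OC2=O)c(O)cc1O` gives 4900 nM, and the gap between the two lies within the scatter of repeated measurements. Compound 3 `CC(C)=CCc1cc(/C=C2\OC(=O)C(c3cc(CC=C(C)C)c(O)cc3O)=C2O)ccc1O` has not yet been measured. It differs from compound 1 in one place: 2-methylprop-1-en-1-yl in place of 2-hydroxy-2-methylpropyl on a saturated chain carbon bound to an aromatic carbon. Within the data shown here, no step between measured compounds bears on this change, so the data give no direction for it. For compound 3 the account expects a step of a 1.2-fold lower number from compound 1 to compound 3 (0.09 log units; within the scatter), within the scatter. The estimate for compound 3 is 2500 nM, with a range from 800 nM to 8000 nM.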

Compound 3, half-maximal inhibitory concentration: 3000 nM
For compound 3 the middle estimate is 1.2-fold (0.08 log units) below the measured one; measured number inside the range.
By their numbers in this assay, from the lowest: compounds 3, 1 and 2 (each within the scatter of the next).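

In this assay, the exchange of 2-hydroxy-2-methylpropyl for 2-methylprop-1-en-1-yl on this saturated chain carbon gives a 1.0-fold lower number from compound 1 to compound 3 (0.01 log units; within the scatter), so the read-out does not separate the two groups at this place. The hydrogen-bond donor and acceptor counted on the leaving group can therefore go without a step beyond the scatter. No measurement here explains why the two groups read alike.

On these data alone, whether an amine, a carboxylic acid or a longer chain at this place would shift the number remains open.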